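Hydroxy for chloroacetamido on the acyclic uracil core

The compounds below may be only part of what the source reports. "The series", "measured", "known", "first", "only" and "open" are said of these compounds alone.

For the measured compounds named here, compound 2 `O=C(CCl)Nc1cn(COC(CO)CO)c(=O)[nH]c1=O` carries the only real number in this small set: in a functional assay on NCI-H460 cells (Homo sapiens) for inhibition, read by MTT assay, with a stated time of 72 h (on this read-out higher numbers stand for weaker inhibition and lower numbers for stronger inhibition), compound 2 gives 24000 nM. Compound 1 `O=c1ccn(COC(CO)CO)c(=O)[nH]1`, the parent without a substituent on that ring carbon, reaches only (the limit of > 100000 nM in this assay, at which 1 of the 2 values shown sits), so the reading for compound 1 is a limit and not a number: > 100000 nM.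

Compound 3 `O=c1[nH]c(=O)n(COC(CO)CO)cc1O` differs from compound 2 by hydroxy in place of ((chloromethyl)carbonyl)amino on an aromatic carbon. Going by the values given here, the single measured step that bears on this change is an at least 4.1-fold lower number from compound 1 to compound 2 (0.61 log units; beyond the scatter), the gain of the very group that compound 3 now gives up. That step started from a limit. Its size is known only as a floor. Among the compounds with values here, removing the group is expected to undo it; the hydroxy that enters in its place has no precedent among the measured compounds, so its own weight cannot be judged from this set. The step is therefore expected to be a 4.2-fold higher number from compound 2 to compound 3 (0.62 log units; beyond the scatter), towards weaker inhibition and beyond the scatter. Compound 3 is estimated at 100000 nM, with a range of 35000 nM to 300000 nM, and a fair chance that this assay again returns only a limit.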

Compound 3, half-maximal inhibitory concentration: > 100000 nM
Compound 3 was reported as a limit (the forecaster's own chance of this, stated with the estimate: 55%); the middle value lies on the limit itself.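

In this assay compound 3 gives > 100000 nM, a limit of the assay and not a number. Hydroxy in place of ((chloromethyl)carbonyl)amino on this aromatic carbon gives an at least 4.1-fold higher number from compound 2 to compound 3 (0.61 log units; beyond the scatter), so a substituent on this carbon is not enough on its own: among the three compounds, a reading short of the limit goes with ((chloromethyl)carbonyl)amino alone, in compound 2. Both ends of the step from compound 1 to compound 3 are limits, so that step cannot be read and hydrogen and hydroxy cannot be ordered at this position, while the series gathers at one reading: the limit of > 100000 nM in this assay, at which 2 of the 3 values shown sit.

Which part of ((chloromethyl)carbonyl)amino goes with the reading of compound 2 stays open: a plain amine on the same carbon, or an acetyl amide without the chlorine, would separate the amide from the chloromethyl end. Also open, on these data alone, is whether a bromomethyl group or a longer alkyl chain on the same carbonyl would shift the reading in either direction.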